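Replacing the 4-fluorobenzyl on the nitrogen with acetyl

The source may hold more compounds than are shown below. What is called first, only, known or untested is meant among the compounds shown, and "the series" means these compounds.

Measured so far:
compound 1 `CC(=O)Oc1ccc2c(c1)C(C)=CC(C)(C)N2Cc1cccc(C)c1`: 28000 nM
compound 2 `CC(=O)Oc1ccc2c(c1)C(C)=CC(C)(C)N2Cc1ccc(F)cc1`: 29000 nM

In an ADME assay on L6 cells (Rattus norvegicus) for cytotoxicity, read by resazurin assay, with a stated time of 70 h (a higher number here means a weaker inhibitor, a lower number a stronger inhibitor), compound 2 gives 29000 nM, which matches compound 1 within the scatter of repeated measurements. The next compound, compound 3 `CC(=O)Oc1ccc2c(c1)C(C)=CC(C)(C)N2C(C)=O`, makes a larger change to the same core: acetyl in place of 4-fluorobenzyl on a nitrogen on an aromatic ring in a ring. Among the measured compounds shown here, the one measured step, a 1.0-fold higher number from compound 1 to compound 2 (0.02 log units; within the scatter), exchanged 3-methylphenyl for 4-fluorophenyl and kept the benzyl-type frame on the nitrogen. For the measured compounds named here, it therefore says little about removing that frame, and no measured compound carries acetyl there. A moderate shift towards a higher number is expected, though with real uncertainty, and the direction is a judgement rather than a measured trend. The expected move is a 2.1-fold higher number from compound 2 to compound 3 (0.32 log units; beyond the scatter). For compound 3 the estimated value is 60000 nM, with an expected range from 20000 nM to 150000 nM.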

Compound 3, half-maximal inhibitory concentration: 160000 nM
Compound 3: the middle estimate sits 2.7-fold (0.43 log units) below what was measured; the whole stated range lies below it.
By their numbers in this assay, from the lowest: compounds 1 and 2 (each within the scatter of the next); then compound 3.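

In this assay, changing only the substituent on the benzyl ring had left the number within the scatter, but replacing the whole benzyl-type group on the nitrogen does move it: acetyl gives a 5.5-fold higher number from compound 2 to compound 3 (0.74 log units; beyond the scatter) and a 5.7-fold higher number from compound 1 to compound 3 (0.76 log units; beyond the scatter). Both steps point the same way, so among these three compounds the number responds more to which kind of group sits on this nitrogen than to the difference between 3-methylbenzyl and 4-fluorobenzyl. No measurement available here explains why the number rises with acetyl.

The change removes an aromatic ring and adds a carbonyl at once, so the compounds shown cannot separate these two parts of the swap. A benzoyl group, which has both the ring and the carbonyl, or a plain ethyl group, which has neither, would pull them apart.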